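The source may hold more compounds than are shown below. What is called first, only, known or untested is meant among the compounds shown, and "the series" means these compounds.

In a functional assay on the whole organism with Mus musculus as the target (on this read-out higher numbers stand for an effect only at larger amounts of compound and lower numbers for an effect already at smaller amounts), three compounds have been measured so far. Compound 1 `C=CCNC(=O)/C(C)=C/c1ccccc1` gives 53.8 mg/kg, compound 2 `C/C(C(=O)NC1CC1)=C(\C)c1cccc(C(F)(F)F)c1` gives 65.5 mg/kg, and compound 3 `C/C(C(N)=O)=C(/C)c1ccc(Cl)cc1` gives 20.9 mg/kg. Compound 3 thus stands at the lowest of the three numbers: compound 1 sits at a higher number, beyond the scatter, and compound 2 at a still higher one, also beyond the scatter. Compound 3 is the only primary amide among the three, while compound 1 carries an allyl group and compound 2 a cyclopropyl group on the amide nitrogen, each joined to a different core.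

Compound 4 `C/C(C(=O)NC1CC1)=C(/C)c1ccc(Cl)cc1` is the cyclopropyl analogue of compound 3, with the change (cyclopropyl in place of hydrogen on an amide-type nitrogen), or in other words amino to cyclopropylamino. Within the data shown here, no measured pair shows this change alone. Compound 2, the other cyclopropylamide, gives 65.5 mg/kg, a larger dose than compound 3, but it differs from compound 3 in more than the amide substituent, so it does not set the step. The expected step is a 1.7-fold higher number from compound 3 to compound 4 (0.22 log units; within the scatter), a moderate move toward a larger dose, not far beyond the scatter. Compound 4 is therefore estimated at 35 mg/kg, with a range from 15 mg/kg to 80 mg/kg.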

Compound 4, dose for half-maximal effect: 11.4 mg/kg
Beside the measured number, compound 4's estimate is 3.1-fold (0.49 log units) above it, and the stated range ends above it.
By their numbers in this assay, from the lowest: compounds 4 and 3 (each within the scatter of the next); then compounds 1 and 2 (each within the scatter of the next).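

In this assay, among these compounds, cyclopropyl in place of hydrogen on the amide-type nitrogen gives a 1.8-fold lower number from compound 3 to compound 4 (0.26 log units; within the scatter), the first reading of this change alone on a shared core. Among the compounds shown here, on this core, the amide hydrogen of compound 3 can therefore give way to cyclopropyl with no difference beyond the scatter, so a primary amide is not needed for a number in this range, which the earlier compounds, each on a different core, could not show. Nothing at hand gives a measured reason for how this pair behaves, and this single pair sets no general rule for the amide nitrogen.

The compounds shown leave open whether an allyl group, a methyl group or a longer chain such as n-butyl on the same nitrogen would also stay within the scatter of compound 3, and whether a carboxylic acid or a nitrile in place of the amide would do so. They also leave open whether hydrogen and cyclopropyl would give as small a step on the cores of compound 1 and compound 2.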